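Reversing the Amide on a Biaryl Ether

The source may report more compounds than this note shows. Statements on the series, on what has been measured and on what is new or still open speak of the compounds shown alone.

In an assay on COS-7 cells for inhibition of patatin-like phospholipase domain-containing protein 2 (Mus musculus) (a lower number here means a stronger inhibitor, a higher number a weaker inhibitor), compound 3 `CCNC(=O)c1cccc(-c2ccc(OCC)cc2)c1` gives 90000 nM. Among the three measured compounds it holds the second highest number: compound 1 `CCOc1ccc(-c2cccc(C)c2)cc1` gives 70000 nM, and compound 2 `CCOc1ccc(-c2cccc(C(=O)N3CCCC3)c2)cc1` gives 160000 nM, with a 1.3-fold higher number from compound 1 to compound 3 (0.11 log units; within the scatter) and a 1.8-fold lower number from compound 2 to compound 3 (0.25 log units; within the scatter), so compound 3 is not separated from either neighbour by more than the usual scatter. Among the compounds with values here, the one step that does exceed the scatter is a 2.3-fold higher number from compound 1 to compound 2 (0.36 log units; beyond the scatter), a modest shift.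

Compound 4 `CCOc1ccc(-c2cccc(NC(C)=O)c2)cc1` differs from compound 3 in one place: acetamido in place of ethylcarbamoyl on an aromatic carbon. Within the data shown here, no measured pair carries this exact change; the nearest guides are the steps that swap or alter the amide unit on the same aromatic carbon, all of which were small. Compound 3 and compound 1 sit within the scatter of each other, as do compound 3 and compound 2. On that basis compound 4 is expected to show no movement beyond the scatter, with a 1.1-fold higher number from compound 3 to compound 4 (0.05 log units; within the scatter). Compound 4 is therefore estimated at 100000 nM, within a range from 40000 nM to 250000 nM.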

Compound 4, half-maximal inhibitory concentration: 200000 nM
Compound 4: middle estimate off by 2.0-fold (0.30 log units), on the low side, within the range that was stated.
By their numbers in this assay, from the lowest: compounds 1, 3, 2 and 4 (each within the scatter of the next, the first and the last beyond it).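

In this assay, the direction of the amide on this aromatic carbon matters: a 2.2-fold higher number from compound 3 to compound 4 (0.35 log units; beyond the scatter) is a step beyond the scatter, whereas exchanging the ethylamino and pyrrolidin-1-yl parts on the carbonyl carbon had stayed within it. Measured against the methyl group, acetamido gives the largest step among these compounds, a 2.9-fold higher number from compound 1 to compound 4 (0.46 log units; beyond the scatter) and thus beyond the scatter, while a 1.3-fold higher number from compound 2 to compound 4 (0.10 log units; within the scatter) leaves compound 4 and compound 2 inseparable within the scatter. No measurement here accounts for why this change moves the number.

From the compounds shown here alone, it remains open whether the shift belongs to the reversed amide itself or to the smaller group, a distinction that a propanamido group on this carbon could draw. Also open, going by these compounds, is how an amine or a carboxylic acid would compare with the methyl group of compound 1 at this position.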